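This account rests on a few compounds, and the source may have more. Where it says the series, first, only, none or still open, it means among the compounds named here.

Compound 2 (`C=CC(=O)Nc1cccc2c1cc(C)n2-c1nc2c(c(NCc3ccccc3)n1)COCC2`) gives 4600 nM in a functional assay on A549 cells (Homo sapiens) for antiproliferative activity, read by CCK-8 assay, with a stated time of 72 h (a lower number here means a stronger inhibitor, a higher number a weaker inhibitor), and compound 1 (`Cc1cc2c(C(N)=O)cccc2n1-c1nc2c(c(NCc3ccccc3)n1)CCCCC2`) gives 2600 nM on the same read-out. These two values lie within the usual scatter of each other, so compound 2 stands level with compound 1. Compound 3 (`Cc1cc2c(NS(C)(=O)=O)cccc2n1-c1nc2c(c(NCc3ccccc3)n1)COCC2`) is still unmeasured. It carries methylsulfonyl in place of vinylcarbonyl on a nitrogen on an aromatic ring. Among the compounds with values here, no pair of measured compounds shows this change, so in this assay the expectation rests on compound 2 at 4600 nM alone, with no shift expected beyond the scatter. The expected change is therefore small (a 1.1-fold higher number from compound 2 to compound 3 (0.04 log units; within the scatter)). Compound 3 is estimated at 5000 nM with an expected range from 1800 nM to 14000 nM once it is measured.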

Compound 3, half-maximal inhibitory concentration: 1600 nM
Compound 3: the middle estimate sits 3.1-fold (0.49 log units) above what was measured, outside the stated range (below it).
By their numbers in this assay, from the lowest: compounds 3, 1 and 2 (each within the scatter of the next, the first and the last beyond it).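

Within the data shown here, at the nitrogen on an aromatic ring, the group carried there changes the read-out in this assay: methylsulfonyl in place of vinylcarbonyl gives a 2.9-fold lower number from compound 2 to compound 3 (0.46 log units; beyond the scatter), the first step between measured compounds that differ in one place. For this pair, activity does not depend on vinylcarbonyl, since the group that enters has the same count of heavy atoms, with sulfur and a second oxygen among them, and the number still falls. Nothing shown here accounts for the size or direction of this step.

On these data alone, it remains open whether this position would accept other groups, such as a plain acetyl, a free amine or a longer chain on the sulfonyl. As far as these compounds go, it is also open whether the same change would act alike on the core of compound 1.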